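Moving the furan attachment point in two related series

The source may report more compounds than this note shows. Statements on the series, on what has been measured and on what is new or still open speak of the compounds shown alone.

Compound 1 `CCCOC(=O)C1=C(C)NC(=S)NC1c1ccco1` and compound 2 `CCCOC(=O)C1=C(C)NC(=S)NC1c1ccoc1` share one core, while compound 3 `CCSC(=O)C1=C(C)NC(=O)NC1c1ccco1` and compound 4 `CCSC(=O)C1=C(C)NC(=O)NC1c1ccoc1` share another; the difference between the two cores is not broken down here. In an assay on membranes from HEK293 cells for displacement of a labelled ligand from adenosine receptor A2b (Homo sapiens), read by scintillation counting, with a stated time of 30 min, tested at 1 uM (a higher number here means more inhibition at the concentration tested (going by the name of the read-out), a lower number less inhibition), compound 1 gives 46% and compound 2 gives 45%. The change between them is furan-3-yl in place of furan-2-yl on a saturated ring carbon, and it produced a number 1 percentage points lower from compound 1 to compound 2 (within the scatter). In this assay compound 3 gives 29%, a lower number than either compound 1 or compound 2, both gaps lying beyond the scatter. Compound 4 carries the same kind of change relative to compound 3, (furan-3-yl in place of furan-2-yl on a saturated ring carbon); the surroundings differ only in that the saturated ring carbon is next to the ring atom that bears a (ethylsulfanyl)carbonyl group here, rather than a propoxycarbonyl group. Because the earlier swap gave a number 1 percentage points lower from compound 1 to compound 2 (within the scatter), compound 4 is expected to land near compound 3, with an estimated step of a number 1 percentage points lower from compound 3 to compound 4 (within the scatter). Compound 4 is therefore estimated at 28% in this assay, with an expected range from 17% to 39%.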

Compound 4, a percentage reported as inhibition, at one concentration (the size of the read-out at that concentration, not a potency): 1%
Compound 4: middle estimate off by 27 percentage points, on the high side; the measured number lies below the stated range.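

In this assay, furan-3-yl in place of furan-2-yl gives a number 28 percentage points lower from compound 3 to compound 4 (beyond the scatter). The same swap therefore does not carry over unchanged from one core to the other: the same change on two cores in this assay, a number 1 percentage points lower (within the scatter) from compound 1 to compound 2 and a number 28 percentage points lower (beyond the scatter) from compound 3 to compound 4, 27 percentage points apart, beyond the scatter of two such steps. This shows that, for these two pairs, the result of moving the furan attachment point depends on the surrounding core, so a step read on one core is a poor guide to the other; it does not show why, or how the swap would behave on any further core.

Still open, on these data alone, is which part of the difference between the two cores matters, the propoxycarbonyl group against the (ethylsulfanyl)carbonyl group or some other part of the core. Also open, as far as these compounds go, is whether the large step on the core of compound 3 would persist with a longer chain on the sulfur or with an amide or a carboxylic acid in place of the (ethylsulfanyl)carbonyl group.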